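The compounds below may be only part of what the source reports. "The series", "measured", "known", "first", "only" and "open" are said of these compounds alone.

In a functional assay on DU-145 cells (Homo sapiens) for cytotoxicity, read by MTT assay (on this read-out lower numbers stand for stronger inhibition and higher numbers for weaker inhibition), compound 1 (`COc1ccc2cc([C@H](C)c3nnc(SCc4ccc(F)cc4)n3-c3ccc(Cl)cc3)ccc2c1`) gives 33600 nM and compound 2 (`COc1ccc2cc([C@H](C)c3nnc(SCc4ccc(F)cc4)n3-c3ccc(F)cc3)ccc2c1`) gives 60200 nM so the two stand within the usual scatter of each other. Compound 3 (`COc1cccc(CSc2nnc([C@@H](C)c3ccc4cc(OC)ccc4c3)n2-c2ccc(F)cc2)c1`) has not yet been measured. The change from compound 2 (3-methoxyphenyl in place of 4-fluorophenyl on a saturated chain carbon bound to a sulfur) puts 3-methoxyphenyl in place of 4-fluorophenyl on a saturated chain carbon bound to a sulfur. Within the data shown here, the one measured step (a 1.8-fold higher number from compound 1 to compound 2 (0.25 log units; within the scatter)) is fluoro in place of chloro on an aromatic carbon. It lies within the scatter and sits at another place in the structure, so it bears only weakly on this change. Among the measured compounds shown here, no measured pair varies the group on that saturated chain carbon, so no step beyond the scatter is expected in this assay and no direction can be given. The expected size, as an estimate, is a 1.3-fold lower number from compound 2 to compound 3 (0.13 log units; within the scatter) with wide uncertainty. For compound 3 the estimated value is 45000 nM (expected range 16000 nM to 120000 nM).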

Compound 3, half-maximal inhibitory concentration: 19200 nM
Beside the measured number, compound 3's estimate is 2.3-fold (0.37 log units) above it; measured number inside the range.
By their numbers in this assay, from the lowest: compounds 3, 1 and 2 (each within the scatter of the next, the first and the last beyond it).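

In this assay, the group on the saturated chain carbon bound to a sulfur proves able to shift the number: 3-methoxyphenyl in place of 4-fluorophenyl gives a 3.1-fold lower number from compound 2 to compound 3 (0.50 log units; beyond the scatter). This is the first single change shown that lies beyond the scatter, whereas fluoro in place of chloro on an aromatic carbon, a change at another place, gives a 1.8-fold higher number from compound 1 to compound 2 (0.25 log units; within the scatter), which stays within it. Nothing available explains why this change shifts the number.

Going by these compounds, a single pair cannot separate the arrival of the methoxy group from the departure of the fluoro, so it remains open how an unsubstituted phenyl or a 4-methoxyphenyl would read at this place. Also open, on these data alone, are how an amine or a carboxylic acid on that ring would read, and whether the step would hold with the chloro of compound 1 in place.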